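Replacing the Trimethoxyphenyl Group: What to Expect

This account rests on a few compounds, and the source may have more. Where it says the series, first, only, none or still open, it means among the compounds named here.

In a functional assay on HT-29 cells (Homo sapiens) for cytotoxicity, read by MTT assay, with a stated time of 72 h (on this read-out lower numbers stand for stronger inhibition and higher numbers for weaker inhibition), compound 1 `CN(C)CCn1cnnc1-c1cc(Oc2ccc(NC(=O)N/N=C/c3ccc(F)cc3F)cc2F)ccn1` gives 960 nM. Compound 2 `COc1cc(/C=N/NC(=O)Nc2ccc(Oc3ccnc(-c4nncn4CCN(C)C)c3)c(F)c2)cc(OC)c1OC` gives 3620 nM in this assay, the higher of the two numbers in hand. For the measured compounds named here, the single measured step, a 3.8-fold higher number from compound 1 to compound 2 (0.58 log units; beyond the scatter), shows that exchanging the group on the carbon with a double bond to nitrogen can shift the result noticeably. Compound 3 `CN(C)CCn1cnnc1-c1cc(Oc2ccc(NC(=O)N/N=C/c3ccc(O)c(O)c3)cc2F)ccn1` differs from compound 2 by 3,4-dihydroxyphenyl in place of 3,4,5-trimethoxyphenyl on a carbon with a double bond to nitrogen. Going by the values given here, no measured step covers this particular exchange, so the expectation is uncertain. Compound 3 is therefore expected to show a 1.8-fold lower number from compound 2 to compound 3 (0.26 log units; within the scatter). Compound 3 is estimated at 2000 nM, with a range from 600 nM to 7000 nM.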

Compound 3, half-maximal inhibitory concentration: 1890 nM
For compound 3 the middle estimate is 1.1-fold (0.02 log units) above the measured one; the range from low to high includes it.
By their numbers in this assay, from the lowest: compounds 1, 3 and 2 (each within the scatter of the next, the first and the last beyond it).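

In this assay, 3,4-dihydroxyphenyl on the carbon with a double bond to nitrogen gives a 1.9-fold lower number from compound 2 to compound 3 (0.28 log units; within the scatter) and also a 2.0-fold higher number from compound 1 to compound 3 (0.29 log units; within the scatter) when it replaces 2,4-difluorophenyl. Compound 3 therefore cannot be separated from either compound, even though it carries hydrogen-bond donors that the other two groups lack, so this position tolerates that exchange in this assay. Nothing available here explains these numbers. As far as these compounds go, whether a simple phenyl, a 4-hydroxyphenyl or a non-aromatic group such as cyclohexyl would fit this position stays open.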